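Fluoro on the pendant phenyl of a shared indole-type core

The source may hold more compounds than are shown below. What is called first, only, known or untested is meant among the compounds shown, and "the series" means these compounds.

Measured so far:
compound 1, `CC(=O)c1cc(-c2ccc(F)cc2)cc2cc(-c3ccccc3)[nH]c12` — 55.7%
compound 2, `COc1ccc(-c2cc3cc(-c4ccccc4)cc(C(C)=O)c3[nH]2)cc1` — 51.6%

Of the compounds shown here, two have been tested in a functional assay on HeLa cells (Homo sapiens) for cytotoxicity, read by MTT assay, with a stated time of 2 days, tested at 10 uM; on this read-out lower numbers stand for a stronger effect and higher numbers for a weaker effect at the one concentration tested. Compound 1 gives 55.7% in that assay. Compound 2 gives 51.6% in this assay, and the two numbers lie within the usual scatter of each other, so neither compound can be told apart from the other on these data.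

Compound 3, `COc1ccc(-c2cc3cc(-c4ccc(F)cc4)cc(C(C)=O)c3[nH]2)cc1`, has not yet been measured. It differs from compound 2 in one place: fluoro in place of hydrogen on an aromatic carbon. Within the data shown here, no pair of measured compounds shows this exact step, so the numbers give no direct guide to its size. The step from compound 2 to compound 3 is expected to be small, a number 1.6 percentage points lower from compound 2 to compound 3 (within the scatter), with no change beyond the scatter in either direction. Compound 3 is estimated to give 50% in this assay, with a range from 36% to 64%.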

Compound 3, a percentage reported as activity, at one concentration (the size of the read-out at that concentration, not a potency): 52%
Beside the measured number, compound 3's estimate is 2 percentage points below it; the range from low to high includes it.
By their numbers in this assay, from the lowest: compounds 2, 3 and 1 (each within the scatter of the next).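

In this assay, among these compounds, phenyl to 4-fluorophenyl with the methoxy group kept in place gives a number 0.4 percentage points higher from compound 2 to compound 3 (within the scatter) as the first direct reading of this change, so fluoro in place of hydrogen at this position, para to a large group, is not told apart from hydrogen on this read-out. With the fluoro kept on that ring, the other single change, the addition of the methoxy group, gives a number 3.7 percentage points lower from compound 1 to compound 3 (within the scatter) and so is not resolved either in this setting. Nothing at hand bears on the cause of these readings.

On these data alone, whether an amine or a carboxylic acid in place of the fluoro would give a step beyond the scatter remains open. As far as these compounds go, each change has been read only once, on a single pair of compounds, so it is also open whether either reading would hold on a different core.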